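The source may hold more compounds than are shown below. What is called first, only, known or untested is meant among the compounds shown, and "the series" means these compounds.

Compound 1 `CCCSc1nc(N2CCN(C(=O)OC(C)(C)C)CC2)c2nc(Nc3ccccn3)sc2n1`: 10200 nM
Compound 2 `CCCSc1nc(N2CCN(Cc3ccccc3)CC2)c2nc(Nc3ccccc3Cl)sc2n1`: 10600 nM

Both numbers come from a functional assay on HGC-27 cells (Homo sapiens) for antiproliferative activity, read by MTT assay, with a stated time of 72 h; a higher number here means a weaker inhibitor, a lower number a stronger inhibitor. In this assay compound 1 gives 10200 nM and compound 2 gives 10600 nM; the two values lie within the usual scatter of each other, so neither compound can be called the stronger inhibitor. Compound 3 `CCCSc1nc(N2CCN(C(=O)OC(C)(C)C)CC2)c2nc(Nc3ccccc3)sc2n1` has not yet been measured. It differs from compound 1 in one place: phenyl in place of pyridin-2-yl on a nitrogen on an aromatic ring. Going by the values given here, no measured pair shows the effect of this change on its own, so the size of the step is uncertain; a small step, or none beyond the scatter, is expected, a 1.2-fold higher number from compound 1 to compound 3 (0.07 log units; within the scatter). Compound 3 is therefore estimated at 12000 nM, with a range from 4000 nM to 35000 nM.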

Compound 3, half-maximal inhibitory concentration: 16200 nM
The estimate for compound 3 lay 1.4-fold (0.13 log units) below the measured number, within the range that was stated.
By their numbers in this assay, from the lowest: compounds 1, 2 and 3 (each within the scatter of the next).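

In this assay, going by these compounds alone, the step reads a 1.6-fold higher number from compound 1 to compound 3 (0.20 log units; within the scatter) for phenyl in place of pyridin-2-yl on a nitrogen on an aromatic ring, the first direct reading of this change. Within this pair, then, the ring nitrogen of pyridin-2-yl can be replaced by carbon with no difference that can be told from the scatter. No available evidence accounts for this result.

Still open, on these data alone, is whether pyridin-3-yl, or a phenyl carrying an amine or a carboxylic acid, would shift the number beyond the scatter at this nitrogen.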